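Chloro on the pendant phenyl of a bis-chalcone core

The source may report more compounds than this note shows. Statements on the series, on what has been measured and on what is new or still open speak of the compounds shown alone.

Compound 1 `Cc1cc(O)c(C(=O)/C=C/c2ccccc2)c(-c2ccccc2)c1C(=O)/C=C/c1ccccc1`: "not active" (no number reported)
Compound 2 `Cc1cc(O)c(C(=O)/C=C/c2ccc(Cl)cc2)c(-c2ccccc2)c1C(=O)/C=C/c1ccc(Cl)cc1`: 30000 nM
Compound 3 `COc1ccc(/C=C/C(=O)c2c(C)cc(O)c(C(=O)/C=C/c3ccc(OC)c(OC)c3)c2-c2ccccc2)cc1OC`: "not active" (no number reported)

Three compounds sharing one core were tested in a functional assay on HeLa cells (Homo sapiens) for cytotoxicity, read by MTT assay, with a stated time of 24 h; a higher number here means a weaker inhibitor, a lower number a stronger inhibitor. Compound 1 `Cc1cc(O)c(C(=O)/C=C/c2ccccc2)c(-c2ccccc2)c1C(=O)/C=C/c1ccccc1` gives no number in this assay; it is reported as "not active" (no number reported). Compound 2 `Cc1cc(O)c(C(=O)/C=C/c2ccc(Cl)cc2)c(-c2ccccc2)c1C(=O)/C=C/c1ccc(Cl)cc1`, which carries a chlorine on each of the two cinnamoyl aryl rings, gives 30000 nM in this assay. Compound 3 `COc1ccc(/C=C/C(=O)c2c(C)cc(O)c(C(=O)/C=C/c3ccc(OC)c(OC)c3)c2-c2ccccc2)cc1OC`, with methoxy groups on those rings, gives "not active" (no number reported). So compound 1 stands among the compounds without a number, and only compound 2 shows measurable cytotoxicity, and that weakly.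

Compound 4 `Cc1cc(O)c(C(=O)/C=C/c2ccccc2)c(-c2ccc(Cl)cc2)c1C(=O)/C=C/c1ccccc1` is the not yet measured analogue. It differs from compound 1 by chloro in place of hydrogen on an aromatic carbon, para to a large group, on the phenyl attached to the core rather than on a cinnamoyl ring. Going by the values given here, no pair of measured compounds shows this exact change, so no step can be quoted. Since compound 1 gives "not active" (no number reported) and compound 2, with two chlorines on other rings, gives only 30000 nM, a single chlorine is expected to bring at most a small gain in this assay, if any beyond the scatter. For compound 4 the half-maximal inhibitory concentration is estimated at 50000 nM, with a range from 15000 nM to 150000 nM.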

Compound 4, half-maximal inhibitory concentration: "not active" (no number reported)
Compound 4: no number reported; no gap can be computed for the estimate.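

Compound 4, like compound 1, carries no number in this assay, so no step can be read between them, and nothing measured here bears on this result. The compounds shown leave open whether phenyl to 4-chlorophenyl changes cytotoxicity at all.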